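Replacing the 2-phenyl-1H-imidazol-1-yl group of compound 3

A few compounds are considered here, and "the series" means these few. Any claim that something is new, unique, unknown or untested is made for them only; others in the source may bear on it.

Measured in a functional assay on HUVEC cells (Homo sapiens), read by scintillation counting and thymidine incorporation, with a stated time of 24 h; on this read-out higher numbers stand for weaker inhibition and lower numbers for stronger inhibition:
- compound 1 `CCC(C)n1ncn(-c2ccc(N3CCN(c4ccc(OC[C@@H]5CO[C@@](CN(C)C)(c6ccc(Cl)cc6Cl)O5)cc4)CC3)cc2)c1=O`: 1400 nM
- compound 2 `CCC(C)n1ncn(-c2ccc(N3CCN(c4ccc(OC[C@@H]5CO[C@@](Cn6cnc(C(F)(F)F)n6)(c6ccc(Cl)cc6Cl)O5)cc4)CC3)cc2)c1=O`: 270 nM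
- compound 3 `CCC(C)n1ncn(-c2ccc(N3CCN(c4ccc(OC[C@@H]5CO[C@@](Cn6ccnc6-c6ccccc6)(c6ccc(Cl)cc6Cl)O5)cc4)CC3)cc2)c1=O`: 136 nM

Compound 3 stands at the low end of these numbers, but not alone: the gap is a 2.0-fold lower number from compound 2 to compound 3 (0.30 log units; within the scatter). The separation from the dimethylamino compound is clear, at a 10-fold lower number from compound 1 to compound 3 (1.01 log units; beyond the scatter). Compound 4 `CCC(C)n1ncn(-c2ccc(N3CCN(c4ccc(OC[C@@H]5CO[C@@](Cn6cnc(C)c6)(c6ccc(Cl)cc6Cl)O5)cc4)CC3)cc2)c1=O` carries 4-methyl-1H-imidazol-1-yl in place of 2-phenyl-1H-imidazol-1-yl on a saturated chain carbon bound to a saturated ring carbon. For the measured compounds named here, no measured step makes this exchange directly. The nearest evidence is the replacement of dimethylamino, with a 5.2-fold lower number from compound 1 to compound 2 (0.71 log units; beyond the scatter) alongside a 10-fold lower number from compound 1 to compound 3 (1.01 log units; beyond the scatter). A modest rise in this assay is therefore expected, namely a 2.2-fold higher number from compound 3 to compound 4 (0.34 log units; beyond the scatter). For compound 4 the estimated value is 300 nM, with an expected range of 100 nM to 900 nM.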

Compound 4, half-maximal inhibitory concentration: 102 nM
Beside the measured number, compound 4's estimate is 2.9-fold (0.47 log units) above it, and the stated range covers the measured number.
By their numbers in this assay, from the lowest: compounds 4, 3 and 2 (each within the scatter of the next, the first and the last beyond it); then compound 1.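

On this saturated chain carbon, the phenyl-bearing group of compound 3 can give way to the smaller 4-methyl-1H-imidazol-1-yl group, and this assay shows a 1.3-fold lower number from compound 3 to compound 4 (0.12 log units; within the scatter) as the step. Unlike compound 3, compound 4 also stands clear of the 3-(trifluoromethyl)-1H-1,2,4-triazol-1-yl group, with a 2.6-fold lower number from compound 2 to compound 4 (0.42 log units; beyond the scatter) as the step. The replacement of dimethylamino remains large, with a 14-fold lower number from compound 1 to compound 4 (1.14 log units; beyond the scatter) as the step.

On these data alone, how a plain 1H-imidazol-1-yl group would read at this place remains open. Nothing available explains these differences.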